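Changing the sulfonamide substituent on a shared core

The source may hold more compounds than are shown below. What is called first, only, known or untested is meant among the compounds shown, and "the series" means these compounds.

Measured compounds:
compound 1, `CC(=O)N1CCC[C@H](NS(C)(=O)=O)[C@@H]1CO[C@H]1CC[C@@H](C(C)C)CC1`: > 100000 nM
compound 2, `CC(=O)N1CCC[C@H](NS(=O)(=O)C(C)C)[C@@H]1CO[C@H]1CC[C@@H](C(C)C)CC1`: > 100000 nM
compound 3, `CCCS(=O)(=O)N[C@H]1CCCN(C(C)=O)[C@H]1CO[C@H]1CC[C@@H](C(C)C)CC1`: > 100000 nM

All three measured compounds share one core and differ only in the group on the sulfonyl sulfur. In a functional assay on CHO-K1 cells for agonist activity at Orexin/Hypocretin receptor type 1 (Homo sapiens), read by FLIPR and calcium flux (on this read-out higher numbers stand for an effect only at larger amounts of compound and lower numbers for an effect already at smaller amounts), compound 1 reaches only the assay limit, > 100000 nM. Compound 2 likewise gives only a limit, > 100000 nM. Compound 3 also stands at a limit, > 100000 nM, so its position is known only as a limit, not as a number, and the same holds for the two other values.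

The steps among them are therefore unreadable: a step that the two limits leave unreadable from compound 1 to compound 2, a step that the two limits leave unreadable from compound 1 to compound 3 and a step that the two limits leave unreadable from compound 2 to compound 3. What is shared is the limit of > 100000 nM in this assay, at which 3 of the 3 values shown sit.

Compound 4, `CC(=O)N1CCC[C@H](N(C)S(C)(=O)=O)[C@@H]1CO[C@H]1CC[C@@H](C(C)C)CC1`, is not yet measured. It differs from compound 3 by methyl(methylsulfonyl)amino in place of (propylsulfonyl)amino on a saturated ring carbon. Going by the values given here, no measured step shows what a methyl on the sulfonamide nitrogen does, and the measured sulfonyl variations all ended at the limit. The expectation is therefore that compound 4 again shows no readable effect in this assay, with an estimated step that the limit leaves unreadable from compound 3 to compound 4. Compound 4 is estimated at 200000 nM, within 50000 nM to 1000000 nM.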

Compound 4, half-maximal effective concentration: > 100000 nM
Compound 4 gave a limit, no number; the forecaster's own chance of this, stated with the estimate: 90%; the middle value is on the limit's open side.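

In this assay compound 4 gives > 100000 nM, a limit and not a number, so its steps to compound 1, compound 2 and compound 3 cannot be read. All four compounds share one result: the limit of > 100000 nM in this assay, at which 4 of the 4 values shown sit. The compounds shown leave open what a methyl on the sulfonamide nitrogen does, and whether any change on the shared core gives a measurable effect.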